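The compounds below may be only part of what the source reports. "The series", "measured", "known", "first", "only" and "open" are said of these compounds alone.

- Compound 1 `CC1(C(=O)NS(=O)(=O)Cc2ccc(F)cc2)CCN(c2nc3c(cc2C#N)C(=O)OC3)CC1`: 35400 nM
- Compound 2 `CC(c1ccccc1)S(=O)(=O)NC(=O)C1CCN(c2nc3c(cc2C#N)C(=O)OC3)CC1`: 4160 nM
- Compound 3 `N#Cc1cc2c(nc1N1CCC(C(=O)NS(=O)(=O)Cc3ccc(F)cc3F)CC1)COC2=O`: 5200 nM

All three values come from a functional assay (Platelet, plasma) for inhibition, with Homo sapiens as the target; on this read-out higher numbers stand for weaker inhibition and lower numbers for stronger inhibition. Compound 3 and compound 2 cannot be told apart on these numbers, and both lie well under the number for compound 1. Compound 1 differs from compound 3 in more than one place, so that gap says little about a single change.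

The next compound is compound 4 `Cc1ccc(CS(=O)(=O)NC(=O)C2CCN(c3nc4c(cc3C#N)C(=O)OC4)CC2)cc1`, which keeps the shared core and alters one group: 4-methylphenyl in place of 2,4-difluorophenyl on a saturated chain carbon bound to a sulfonyl sulfur. In words, this is 4-methylphenyl in place of 2,4-difluorophenyl on a saturated chain carbon bound to a sulfonyl sulfur, or 2,4-difluorobenzyl to 4-methylbenzyl when cut one bond further out.

Among the compounds with values here, only one measured step bears on this. It also swaps the group on the sulfonyl sulfur: a 1.3-fold higher number from compound 2 to compound 3 (0.10 log units; within the scatter). Within the data shown here, that swap left the number within the scatter, but no measured compound carries the 4-methylbenzyl group, so the evidence is indirect. A similar swap is therefore expected to do little here, and the expected change is a 1.1-fold lower number from compound 3 to compound 4 (0.03 log units; within the scatter), which means no shift beyond the scatter is anticipated. The estimated value for compound 4 is 4800 nM, with an expected range from 1900 nM to 12000 nM.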

Compound 4, half-maximal inhibitory concentration: 4280 nM
Compound 4: middle estimate off by 1.1-fold (0.05 log units), on the high side; measured number inside the range.
By their numbers in this assay, from the lowest: compounds 2, 4 and 3 (each within the scatter of the next); then compound 1.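

In this assay, exchanging 2,4-difluorophenyl for 4-methylphenyl on a saturated chain carbon bound to a sulfonyl sulfur gives a 1.2-fold lower number from compound 3 to compound 4 (0.08 log units; within the scatter), so fluorine atoms on this ring and a methyl group cannot be told apart on these numbers. Within the data shown here, measured against the branched group, 4-methylbenzyl in place of 1-phenylethyl on a sulfonyl sulfur gives a 1.0-fold higher number from compound 2 to compound 4 (0.01 log units; within the scatter), which means that 1-phenylethyl, 2,4-difluorobenzyl and 4-methylbenzyl now all lie within the scatter of one another, a wider view of this position than the single swap available before, and one that holds for compounds 2, 3 and 4 only. Nothing measured on these compounds explains this flat picture.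

On these data alone, all three groups carry a six-membered aromatic ring of carbon only, so it remains open whether a saturated cyclohexyl ring, or an amine or a carboxylic acid on the phenyl ring, would shift the number beyond the scatter. A longer chain between the ring and the sulfonyl sulfur is equally untested by the compounds shown here, and its effect on this read-out cannot be judged from them.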